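A few compounds are considered here, and "the series" means these few. Any claim that something is new, unique, unknown or untested is made for them only; others in the source may bear on it.

Measured compounds:
- compound 1 `O=C1/C(=C/c2ccncc2)CNC/C1=C\c1ccccc1F`: 14200 nM
- compound 2 `O=C1/C(=C/c2ccncc2)CN(S(=O)(=O)c2ccccc2)C/C1=C\c1ccccc1F`: 8400 nM

In a functional assay on QGY-7703 cells (Homo sapiens) for cytotoxicity, read by MTT assay, with a stated time of 24 h (a lower number here means a stronger inhibitor, a higher number a weaker inhibitor), compound 2 gives 8400 nM. For the measured compounds named here, only one other compound has a number to compare it with, and compound 1 gives 14200 nM, so the two cannot be told apart. The measured step is a 1.7-fold lower number from compound 1 to compound 2 (0.23 log units; within the scatter).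

The next compound is compound 3 `CC(=O)Nc1ccc(S(=O)(=O)N2C/C(=C\c3ccncc3)C(=O)/C(=C/c3ccccc3F)C2)cc1`, which carries acetamido in place of hydrogen on an aromatic carbon, para to a large group, turning phenyl into 4-acetamidophenyl: acetamido in place of hydrogen on an aromatic carbon. Going by the values given here, only one measured step bears on this change, and it bears indirectly. That step, a 1.7-fold lower number from compound 1 to compound 2 (0.23 log units; within the scatter), put phenylsulfonyl on the ring nitrogen and did not move the number beyond the scatter. Among the compounds with values here, no measured compound carries any substituent on that phenyl, so the data give no direction for this change. No shift beyond the scatter is therefore expected in this assay, although the uncertainty is wide. The expected step is a 1.1-fold lower number from compound 2 to compound 3 (0.05 log units; within the scatter). For compound 3 the estimated value is 7500 nM, with an expected range of 2500 nM to 20000 nM.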

Compound 3, half-maximal inhibitory concentration: 13700 nM
The estimate for compound 3 lay 1.8-fold (0.26 log units) below the measured number; low and high end bracket the measured number.
By their numbers in this assay, from the lowest: compounds 2, 3 and 1 (each within the scatter of the next).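

For the compounds shown here, compound 3 is the first compound here with a substituent on the phenyl of the phenylsulfonyl group, so it gives the first direct reading at this place. In this assay, putting acetamido on this aromatic carbon, para to a large group, gives a 1.6-fold higher number from compound 2 to compound 3 (0.21 log units; within the scatter), which means that turning phenyl into 4-acetamidophenyl cannot be told apart from leaving the phenyl unsubstituted. The reading therefore shows that this one group, with its added hydrogen-bond donor and acceptor, does not shift the number beyond the scatter in this assay, though nothing available explains this result.

This single step cannot show whether the same aromatic carbon is generally insensitive to substitution, or whether acetamido simply happens to leave the number in place. As far as these compounds go, it remains open whether a primary amine, a carboxylic acid, a methoxy group, a chlorine atom or a longer acylamino chain at this place would move the number beyond the scatter, and in which direction.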